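The compounds below may be only part of what the source reports. "The series", "measured", "known", "first", "only" and "open" are said of these compounds alone.

Measured so far in a functional assay on HL-60 cells (Homo sapiens) for antiproliferative activity, with a stated time of 24 h; a lower number here means a stronger inhibitor, a higher number a weaker inhibitor:
Compound 1 `NC(=O)c1c(NC(=O)c2ccccc2Cl)sc2c1CCNC2` gives 18600 nM
Compound 2 `N#Cc1ccccc1CN1CCc2c(sc(NC(=O)c3ccccc3Cl)c2C(N)=O)C1` gives 10400 nM
Compound 3 `NC(=O)c1c(NC(=O)c2ccccc2Cl)sc2c1CCN(Cc1ccccc1Cl)C2` gives 2900 nM

Compound 3 has the lowest number of the three and is the most potent, with both of its gaps beyond the scatter. Compound 4 `NC(=O)c1c(NC(=O)c2ccccc2Cl)sc2c1CCN(Cc1cc(Cl)cc(Cl)c1)C2` has not yet been measured. It differs from compound 3 by 3,5-dichlorophenyl in place of 2-chlorophenyl on a saturated chain carbon bound to an amine nitrogen in a ring.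

Going by the values given here, three measured steps bear on this change, though none of them shows the same exchange. Putting 2-cyanobenzyl in place of hydrogen gave a 1.8-fold lower number from compound 1 to compound 2 (0.25 log units; within the scatter), while 2-chlorobenzyl in the same place gave a 6.4-fold lower number from compound 1 to compound 3 (0.81 log units; beyond the scatter). Chloro in place of cyano gave a 3.6-fold lower number from compound 2 to compound 3 (0.55 log units; beyond the scatter), so the chlorinated benzyl of compound 3 holds the lowest value so far. That supports only a cautious expectation of a small further fall, no larger than these modest steps and probably within the scatter. In this assay the expected step is a 1.4-fold lower number from compound 3 to compound 4 (0.14 log units; within the scatter), and its direction remains uncertain. For compound 4 the estimated value is 2100 nM, with an expected range from 800 nM to 5500 nM.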

Compound 4, half-maximal inhibitory concentration: 15800 nM
Compound 4: middle estimate off by 7.5-fold (0.88 log units), on the low side; the whole stated range lies below it.
By their numbers in this assay, from the lowest: compound 3; then compounds 2, 4 and 1 (each within the scatter of the next).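

In this assay, the benzyl group on the ring amine nitrogen proves sensitive to how it is chlorinated: 3,5-dichlorobenzyl in place of 2-chlorobenzyl gives a 5.4-fold higher number from compound 3 to compound 4 (0.74 log units; beyond the scatter), so the advantage of compound 3 does not extend to every chlorinated benzyl. The other two steps, a 1.5-fold higher number from compound 2 to compound 4 (0.18 log units; within the scatter) and a 1.2-fold lower number from compound 1 to compound 4 (0.07 log units; within the scatter), show that 3,5-dichlorobenzyl cannot be told apart in this assay from either 2-cyanobenzyl or hydrogen at this position, which leaves the 2-chlorobenzyl of compound 3 alone in standing clear of the other three compounds. Nothing available here accounts for this difference between the two chlorinated benzyl groups.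

The change from compound 3 to compound 4 alters the number of chlorine atoms and their places together, so the compounds shown leave open which of the two matters. They also leave open how a plain benzyl, or a benzyl carrying a bromine or a methoxy group, would compare on this nitrogen.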